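Benzylsulfanyl aryl variation on the shared core

The source may hold more compounds than are shown below. What is called first, only, known or untested is meant among the compounds shown, and "the series" means these compounds.

The shared core is that of compound 1 `Cc1cc(Nc2cc(-c3ccccc3)[nH]n2)n2ncnc2n1`. In a functional assay on MCF7 cells (Homo sapiens) for inhibition, read by MTT assay, with a stated time of 72 h (on this read-out higher numbers stand for weaker inhibition and lower numbers for stronger inhibition), compound 1 reaches only a limit, > 50000 nM. That limit sits at the limit of > 50000 nM in this assay, at which 1 of the 3 values shown sits. Compound 2 `Cc1cc(Nc2cc(-c3ccccc3)[nH]n2)n2nc(SCc3cccc(Br)c3)nc2n1` gives 5140 nM in this assay, and compound 3 `Cc1cc(Nc2cc(-c3cccs3)[nH]n2)n2nc(SCc3ccc(Br)cc3)nc2n1` gives 5370 nM. Compound 2 holds the lowest of the two numbers, but compound 3 lies within the scatter of it, so no order between the two is read. For the measured compounds named here, the only step with a number, an at least 9.7-fold lower number from compound 1 to compound 2 (0.98 log units; beyond the scatter), concerns the whole (3-bromobenzyl)sulfanyl group entering in place of hydrogen, and it moves the number from the limit to a measured value.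

Compound 4 `Cc1cc(Nc2cc(-c3ccccc3)[nH]n2)n2nc(SCc3cccc4ccccc34)nc2n1` differs from compound 2 by naphthalen-1-yl in place of 3-bromophenyl on a saturated chain carbon bound to a sulfur. Going by the values given here, no measured step changes the aryl part of the benzylsulfanyl group alone; the pair of compound 2 and compound 3, which differ in more than one place, gives values within the scatter of each other. The step of a 1.0-fold lower number from compound 2 to compound 4 (0.01 log units; within the scatter) is therefore expected to stay within the scatter. For compound 4 the estimate in this assay is 5000 nM, with a range from 1500 nM to 17000 nM.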

Compound 4, half-maximal inhibitory concentration: 7560 nM
Beside the measured number, compound 4's estimate is 1.5-fold (0.18 log units) below it; the range from low to high includes it.
By their numbers in this assay, from the lowest: compounds 2, 3 and 4 (each within the scatter of the next). At a limit, above all of these: compound 1.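

In this assay, for the compounds shown here, naphthalen-1-yl in place of 3-bromophenyl on a saturated chain carbon bound to a sulfur gives a 1.5-fold higher number from compound 2 to compound 4 (0.17 log units; within the scatter) as the first measured step confined to the aryl part of this group. At this position, 3-bromophenyl with 7 heavy atoms and naphthalen-1-yl with 10 heavy atoms, which has 2 aromatic rings and no bromine, therefore give values within the scatter of each other. Nothing measured here bears on why these two aryl groups read alike.

From the compounds shown here alone, how an aryl group carrying an amine or a carboxylic acid would read at this position remains open. Also open, going by these compounds, is the effect of a longer chain in place of the single saturated chain carbon bound to a sulfur.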